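Swapping the Urea Aryl Group: Expected Growth Inhibition

The source may report more compounds than this note shows. Statements on the series, on what has been measured and on what is new or still open speak of the compounds shown alone.

Compound 1 `O=C(Nc1cccc(-n2cc(-c3ccncc3)c(-c3ccc(Cl)c(O)c3)n2)c1)Nc1cccc(C(F)(F)F)c1`: > 32500 nM (a limit)
Compound 2 `COc1cc(-c2nn(-c3cccc(NC(=O)Nc4cc(C(F)(F)F)cc(C(F)(F)F)c4)c3)cc2-c2ccncc2)ccc1Cl`: 2190 nM
Compound 3 `COc1cc(-c2nn(-c3cccc(NC(=O)c4cccc(C(F)(F)F)c4)c3)cc2-c2ccncc2)ccc1Cl`: > 50000 nM (a limit)

In a functional assay on IGROV-1 cells (Homo sapiens) for inhibition, read by sulforhodamine B assay, with a stated time of 48 h (a lower number here means a stronger inhibitor of growth, a higher number a weaker inhibitor of growth), compound 1 gives only a limit, > 32500 nM, and no exact number is known for it. It sits at the limit of > 32500 nM in this assay, at which 1 of the 3 values shown sits. Compound 3 also stands at a limit in this assay, namely (the limit of > 50000 nM in this assay, at which 1 of the 3 values shown sits). For the measured compounds named here, compound 2 is the only one of the three with a measured number, 2190 nM; it differs from the other two in more than one place, so no single step between measured compounds can be read off.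

Compound 4 `O=C(Nc1cccc(-n2cc(-c3ccncc3)c(-c3ccc(Cl)c(O)c3)n2)c1)Nc1ccc(Cl)c(Cl)c1` is built from compound 1 by one change: 3,4-dichlorophenyl in place of 3-(trifluoromethyl)phenyl on an amide-type nitrogen. With compound 1 known only as a limit, the size of the step cannot be anchored on a number. The step from compound 1 to compound 4 is expected to be an at least 1.6-fold lower number from compound 1 to compound 4 (0.21 log units; that floor lies within the scatter), within the range a limit leaves open. Compound 4 is estimated at 20000 nM in this assay, expected between 4000 nM and 80000 nM, with a fair chance that only a limit is again reported.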

Compound 4, concentration for total growth inhibition: > 32500 nM
Compound 4 gave a limit, no number; the forecaster's own chance of this, stated with the estimate: 45%; middle value at least 1.6-fold (0.21 log units) away from the limit.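

Compound 1 and compound 4 both give only a limit in this assay, so no step can be read between them: the limit of > 32500 nM in this assay, at which 2 of the 4 values shown sit.

The compounds shown leave open whether 3,4-dichlorophenyl or 3-(trifluoromethyl)phenyl on the amide-type nitrogen gives the stronger growth inhibition.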